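Swapping a methoxypyrrolidine for a basic pyrazole side chain

A few compounds are considered here, and "the series" means these few. Any claim that something is new, unique, unknown or untested is made for them only; others in the source may bear on it.

Measured so far:
Compound 1, `C[C@@H]1CN(c2sc(C(F)(F)F)nc2-c2nc3ccccc3[nH]2)CCN1C(=O)Cn1ccc(C(=O)O)n1`, gives 5570 nM in a functional assay on Venous blood for antagonist activity at C-X-C chemokine receptor type 3 (Homo sapiens), read by flow cytometry, with a stated time of 30 min, in the presence of a further agent that is not named here; a higher number here means a weaker inhibitor, a lower number a stronger inhibitor.
Compound 2, `COC1CCN(CC(=O)N2CCN(c3sc(C(F)(F)F)nc3-c3nc4ccccc4[nH]3)C[C@H]2C)C1`, gives 3380 nM in this assay.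

Among the compounds with values here, compound 2 has the lowest of the two numbers, but its only neighbour, compound 1, lies within the scatter, so the two cannot be ranked. That one step, a 1.6-fold lower number from compound 1 to compound 2 (0.22 log units; within the scatter), replaced the 3-carboxy-1H-pyrazol-1-yl group with 3-methoxypyrrolidin-1-yl at the same position and moved the number only a little. Compound 3, `Cc1nn(CC(=O)N2CCN(c3sc(C(F)(F)F)nc3-c3nc4ccccc4[nH]3)C[C@H]2C)cc1CN(C)C`, changes that same position again: 4-((dimethylamino)methyl)-3-methyl-1H-pyrazol-1-yl in place of 3-methoxypyrrolidin-1-yl on a saturated chain carbon bound to a carbonyl carbon. Only this single, small step bears on the new change, and it gives no reason to expect a large move in either direction. The expectation for compound 3 is therefore a step of a 1.2-fold lower number from compound 2 to compound 3 (0.08 log units; within the scatter), within the scatter. Compound 3 is estimated at 2800 nM, with a likely range from 900 nM to 9000 nM.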

Compound 3, half-maximal inhibitory concentration: 330 nM
Estimate against measurement, compound 3: 8.5-fold (0.93 log units) above; the whole stated range lies above it.
By their numbers in this assay, from the lowest: compound 3; then compounds 2 and 1 (each within the scatter of the next).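

The position on a saturated chain carbon bound to a carbonyl carbon is far from indifferent in this assay: placing 4-((dimethylamino)methyl)-3-methyl-1H-pyrazol-1-yl there gives a 10-fold lower number from compound 2 to compound 3 (1.01 log units; beyond the scatter), a change the earlier swap, which stayed within the scatter, gave no sign of. The pyrazole ring alone does not account for this, as compound 1 also carries a pyrazole, yet the change of its substituents gives a 17-fold lower number from compound 1 to compound 3 (1.23 log units; beyond the scatter). Nothing available explains why this group does so much better.

The dimethylamino group and the methyl group enter together in compound 3, so the compounds shown do not separate their shares in the step. A pyrazole carrying only the methyl group, or a longer chain bearing the dimethylamino group, would speak to that question.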